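The source may report more compounds than this note shows. Statements on the series, on what has been measured and on what is new or still open speak of the compounds shown alone.

In a functional assay on DU-145 cells (Homo sapiens) for cytotoxicity, read by trypan blue exclusion, with a stated time of 96 h (a higher number here means a weaker inhibitor, a lower number a stronger inhibitor), compound 1 `COc1cc(OC)c(/C=C/SCc2ccc(OC)c([N+](=O)[O-])c2)c(OC)c1` gives 5000 nM, while compound 2 `COC(=O)C(F)(F)Nc1cc(CS(=O)(=O)/C=C/c2c(OC)cc(OC)cc2OC)ccc1OC` gives 250 nM. Compound 2 thus holds the lower of the two numbers, and the gap between them lies beyond the scatter of repeated measurements. Still without a measurement in this assay is compound 3 `COc1cc(OC)c(/C=C/S(=O)(=O)Cc2ccc(OC)c(N[C@@H](C)C(=O)O)c2)c(OC)c1`, which shares the core of compound 2 but carries 1-carboxyethyl in place of difluoro(methoxycarbonyl)methyl on a nitrogen on an aromatic ring. Going by the values given here, no measured pair of compounds shows what such a change does, and the expectation here is correspondingly loose. A step within the scatter is expected, leaning slightly toward a lower number, and the estimated step of a 1.7-fold lower number from compound 2 to compound 3 (0.22 log units; within the scatter) reflects this. Compound 3 is expected at 150 nM, with an estimated range of 30 nM to 800 nM.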

Compound 3, half-maximal inhibitory concentration: 25 nM
Compound 3: middle estimate off by 6.0-fold (0.78 log units), on the high side; the measured number lies below the stated range.
By their numbers in this assay, from the lowest: compound 3; then compound 2; then compound 1.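

Moving the nitrogen on an aromatic ring from difluoro(methoxycarbonyl)methyl to 1-carboxyethyl in this assay gives a 10-fold lower number from compound 2 to compound 3 (1.00 log units; beyond the scatter) and so shows that this position is sensitive to the group it carries, which compound 1 could not show, since it differs from compound 2 in more than one place. The change is a composite one: the entering group has no fluorine and brings a hydrogen-bond donor and a defined stereocentre, and this single pair cannot separate these differences. Nothing measured here accounts for the step.

The compounds shown leave open how the methyl ester of 1-carboxyethyl or the opposite stereocentre would read on that nitrogen. Also open, from the compounds shown here alone, is whether a plain carboxymethyl group or a longer carboxylic acid chain would read like 1-carboxyethyl.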